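Trifluoromethyl Gives Way to Fluoro: Expected Drop

The source may report more compounds than this note shows. Statements on the series, on what has been measured and on what is new or still open speak of the compounds shown alone.

Of the compounds shown here, three built on one shared core have been measured in a functional assay on CHO cells for agonist activity at adenosine receptor A1 (Homo sapiens), read by fluorescence and ERK phosphorylation, with stated times of 30 min and 1.5 h, tested at 10 uM; on this read-out lower numbers stand for a weaker effect and higher numbers for a stronger effect at the one concentration tested. Compound 1 `Nc1scc(-c2cccc(C(F)(F)F)c2)c1C(=O)c1ccccc1` gives 59%. Compound 2 `Nc1scc(-c2cc(C(F)(F)F)cc(C(F)(F)F)c2)c1C(=O)c1ccccc1`, which carries a second trifluoromethyl group, gives 93%. Compound 3 `Nc1scc(-c2cccc(C(F)(F)F)c2)c1C(=O)c1ccc(Cl)cc1`, which carries a chloro group on the ring attached to the carbonyl, gives 73%. Compound 3 thus stands second highest of the three: the step of a number 14 percentage points higher from compound 1 to compound 3 (beyond the scatter) places it above compound 1, while the value of compound 2 is higher still.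

Compound 4 `Nc1scc(-c2cccc(F)c2)c1C(=O)c1ccc(Cl)cc1` has not yet been measured. It differs from compound 3 in one place: fluoro in place of trifluoromethyl on an aromatic carbon. The measured step that bears most on this change is a number 34 percentage points higher from compound 1 to compound 2 (beyond the scatter), in which adding a trifluoromethyl group to this ring raised the read-out strongly; in compound 4 a trifluoromethyl group is instead removed from this ring and fluoro put in its place. The step of a number 14 percentage points higher from compound 1 to compound 3 (beyond the scatter) concerns the chloro group that compound 4 keeps, so it says nothing about this change. The read-out of compound 4 is therefore expected to fall by a sizeable amount, a number 28 percentage points lower from compound 3 to compound 4 (beyond the scatter), though how much of the effect fluoro retains cannot be judged from these three compounds. Compound 4 is estimated at 45%, with a likely range of 20% to 70%.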

Compound 4, a percentage reported as activity, at one concentration (the size of the read-out at that concentration, not a potency): 90%
The estimate for compound 4 lay 45 percentage points below the measured number; measured number above the stated range.
By their numbers in this assay, from the lowest: compound 1; then compound 3; then compounds 4 and 2 (each within the scatter of the next).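

The change from trifluoromethyl to fluoro on this ring gives a number 17 percentage points higher from compound 3 to compound 4 (beyond the scatter) in this assay, so trifluoromethyl is not needed at this position for a strong read-out, and the much smaller fluoro group serves at least as well here. Among these compounds, until now the only change on this ring was the added second trifluoromethyl group, a number 34 percentage points higher from compound 1 to compound 2 (beyond the scatter), which could suggest that a bigger group on this ring raises the number; compound 4 goes against that reading, so the size of the group alone does not track the read-out across these compounds. The compounds shown offer no measurement that explains why fluoro gives the higher number here.

Going by these compounds, whether the same exchange would raise the number without the chloro group on the ring attached to the carbonyl stays open, since compound 3 and compound 4 both carry it. Also open, on these data alone, is how this position would respond to a plain hydrogen, or to a group of another kind, such as a methoxy group, an amine or a carboxylic acid, in the place of fluoro.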